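The source may hold more compounds than are shown below. What is called first, only, known or untested is meant among the compounds shown, and "the series" means these compounds.

Measured in a functional assay on MCF7 cells (Homo sapiens) for inhibition, read by MTT assay, with a stated time of 72 h; a higher number here means a weaker inhibitor, a lower number a stronger inhibitor:
compound 1 `Cc1cc(Nc2cc(-c3ccccc3)[nH]n2)n2nc(SCc3c(Cl)cccc3Cl)nc2n1`: 3230 nM
compound 2 `Cc1cc(Nc2cc(-c3cccs3)[nH]n2)n2nc(SCc3ccc(Br)cc3)nc2n1`: 5370 nM
compound 3 `Cc1cc(Nc2cc(-c3ccc(F)cc3)[nH]n2)n2nc(SCc3ccc(Br)cc3)nc2n1`: 4570 nM

The three numbers lie within the scatter of one another, so compound 1 is not separated from compound 3 or from compound 2 in this assay. Among the measured compounds shown here, the only step between measured compounds, a 1.2-fold lower number from compound 2 to compound 3 (0.07 log units; within the scatter), concerns a group on an aromatic carbon and leaves the sulfur-bearing chain untouched.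

Compound 4 `C=CCSc1nc2nc(C)cc(Nc3cc(-c4ccccc4)[nH]n3)n2n1` differs from compound 1 by vinyl in place of 2,6-dichlorophenyl on a saturated chain carbon bound to a sulfur. For the measured compounds named here, no measured step bears on this change; the one step available sits elsewhere and is within the scatter. The data therefore give no direct guide. The expectation is a moderately higher number for compound 4, a 2.2-fold higher number from compound 1 to compound 4 (0.34 log units; beyond the scatter), with wide uncertainty. Compound 4 is estimated at 7000 nM, range 2500 nM to 20000 nM.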

Compound 4, half-maximal inhibitory concentration: > 50000 nM
Compound 4 was reported as a limit; the forecaster's own chance of this, stated with the estimate: 15%; at least 7.1-fold (0.85 log units) between middle value and limit.
By their numbers in this assay, from the lowest: compounds 1, 3 and 2 (each within the scatter of the next). At a limit, above all of these: compound 4.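

Among the compounds shown here, the change from 2,6-dichlorobenzyl to allyl gives an at least 15-fold higher number from compound 1 to compound 4 (1.18 log units; beyond the scatter) in this assay, the only step that lies beyond the scatter. On these data alone, the value of compound 4 is a limit of the assay and not a number, so the true size of this step stays unknown. The group on this saturated chain carbon bound to a sulfur therefore matters to the read-out, which the earlier step on an aromatic carbon could not show. The ring and the two chlorines leave together, so their shares cannot be told apart. Plain benzyl or a longer chain such as hexyl at this place would test this.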